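The source may report more compounds than this note shows. Statements on the series, on what has been measured and on what is new or still open speak of the compounds shown alone.

Measured so far in a functional assay (blood) for inhibition, with Homo sapiens as the target; a lower number here means a stronger inhibitor, a higher number a weaker inhibitor:
- compound 1 `CC(O)c1cc(-c2ccccc2)c2ccc(OCc3cccc(C4(O)CCOCC4)c3)cc2c1`: 675 nM
- compound 2 `COC(=O)c1cc(-c2ccccc2)c2ccc(OCc3cccc(C4(O)CCOCC4)c3)cc2c1`: 100 nM
- compound 3 `N#Cc1cc(-c2ccccc2)c2ccc(OCc3cccc(C4(O)CCOCC4)c3)cc2c1`: 100 nM

Compound 3 stands level with compound 2, and together they hold the lowest of the three numbers. Compound 4 `Cn1nnc(-c2cc(-c3ccccc3)c3ccc(OCc4cccc(C5(O)CCOCC5)c4)cc3c2)n1` keeps the shared core and changes one group, with 2-methyl-2H-tetrazol-5-yl in place of cyano on an aromatic carbon.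

All three measured steps concern this same place. Two are modest and beyond the scatter: a 6.8-fold lower number from compound 1 to compound 2 (0.83 log units; beyond the scatter) and a 6.8-fold lower number from compound 1 to compound 3 (0.83 log units; beyond the scatter). The third is no change at the digits printed from compound 2 to compound 3 (within the scatter), within the scatter. The place can therefore move the number, but two quite different groups gave the same value. No tetrazole has been measured, so the direction is poorly defined, and no step beyond the scatter is expected in this assay. The expected change is a 1.2-fold higher number from compound 3 to compound 4 (0.08 log units; within the scatter). The estimate for compound 4 is 120 nM, with an expected range of 40 nM to 400 nM.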

Compound 4, half-maximal inhibitory concentration: 310 nM
The estimate for compound 4 lay 2.6-fold (0.41 log units) below the measured number, and the stated range covers the measured number.
By their numbers in this assay, from the lowest: compounds 2 and 3 (each within the scatter of the next); then compound 4; then compound 1.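

In this assay the position proves less forgiving than the equal values of compound 2 and compound 3 suggested, with a 3.1-fold higher number from compound 3 to compound 4 (0.49 log units; beyond the scatter) and a 3.1-fold higher number from compound 2 to compound 4 (0.49 log units; beyond the scatter), so that match does not extend to 2-methyl-2H-tetrazol-5-yl. The tetrazole is still better tolerated than 1-hydroxyethyl, with a 2.2-fold lower number from compound 1 to compound 4 (0.34 log units; beyond the scatter), which places compound 4 on a third level, separate from both compound 1 and the pair of compound 2 and compound 3. Nothing on hand accounts for the rise from the nitrile to this ring with its six heavy atoms.

The compounds shown leave open whether the ring itself or its methyl group sets this level. They also leave open how a tetrazole without the methyl group, a carboxylic acid or a primary amide would rank on the same aromatic carbon.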